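This account rests on a few compounds, and the source may have more. Where it says the series, first, only, none or still open, it means among the compounds named here.

The series rests on a shared core, seen in compound 1 `COc1cc2c(cc1OC)C(CC(=O)O)CC2`, where the carbonyl carbon carries a hydroxy group. In a functional assay on the whole organism (strain Wistar) for inhibition, with Rattus norvegicus as the target, read by paw edema, with a stated time of 4 h, at a dose of 100 mg/kg (on this read-out higher numbers stand for more inhibition at the one dose given (going by the name of the read-out) and lower numbers for less inhibition), compound 1 gives 23.9%. Compound 2 `COc1cc2c(cc1OC)C(CC(=O)Nc1cccc(Cl)c1)CC2` carries a (3-chlorophenyl)amino group in that place and gives 25.8%, a step of a number 1.9 percentage points higher from compound 1 to compound 2 (within the scatter). Compound 3 `COc1cc2c(cc1OC)C(CC(=O)Nc1ccc(Cl)cc1)CC2` carries a (4-chlorophenyl)amino group and gives 60.9%, which is the highest of the three numbers; its steps are a number 37 percentage points higher from compound 1 to compound 3 (beyond the scatter) and a number 35.1 percentage points higher from compound 2 to compound 3 (beyond the scatter).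

Compound 4 `COc1cc2c(cc1OC)C(CC(=O)Nc1ccccc1C)CC2` has not yet been measured. It differs from compound 3 by 2-methylphenyl in place of 4-chlorophenyl on an amide-type nitrogen. Within the data shown here, the only measured step that touches this position is the one in which the pattern of the single ring on the amide-type nitrogen was changed, and it was large: a number 35.1 percentage points higher from compound 2 to compound 3 (beyond the scatter). That step shows that moving from one ring pattern to another can shift the read-out strongly, and that the 4-chlorophenyl pattern of compound 3 is the only one that produced a large number. Among the measured compounds shown here, no measured compound carries a 2-methylphenyl group, so the direction for compound 4 is uncertain, but a large change from compound 3 is more probable than none. Compound 4 is therefore expected to give about 32%, within 12% to 58%, an estimated step of a number 28.9 percentage points lower from compound 3 to compound 4 (beyond the scatter).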

Compound 4, a percentage reported as inhibition, in the whole organism at one dose (the size of the read-out at that dose, not a potency): 25%
Estimate against measurement, compound 4: 7 percentage points above; low and high end bracket the measured number.
By their numbers in this assay, from the lowest: compounds 1, 4 and 2 (each within the scatter of the next); then compound 3.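

Against this assay, the change to 2-methylphenyl on the amide-type nitrogen gives a number 35.9 percentage points lower from compound 3 to compound 4 (beyond the scatter), so a second ring pattern now loses what the 4-chlorophenyl group of compound 3 shows. Among these compounds, the other two steps place compound 4 level with the 3-chlorophenyl amide and with the acid, at a number 0.8 percentage points lower from compound 2 to compound 4 (within the scatter) and a number 1.1 percentage points higher from compound 1 to compound 4 (within the scatter), which means that two of the three amides cannot be told apart from the acid and that an aryl amide at this place does not by itself raise the read-out; compound 3 is the one compound that goes against this. No measurement is at hand that would explain why the 4-chlorophenyl group stands apart from the other two ring patterns.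

Compound 4 differs from compound 3 both in the group on the ring and in the ring pattern, so the compounds shown do not tell which of the two changes goes with the lower number. A 2-chlorophenyl or a 4-methylphenyl group on the amide-type nitrogen would separate the two, and an unsubstituted phenyl group would show what the ring alone gives.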